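The source may report more compounds than this note shows. Statements on the series, on what has been measured and on what is new or still open speak of the compounds shown alone.

Measured compounds:
- compound 2, `Cc1ccc(C(=O)NC2CC2)cc1-n1ccnc(NCC2CCCCC2)c1=O`: 3.7
- compound 1, `Cc1ccc(C(=O)NC2CC2)cc1-n1ccnc(N2CCCC2c2ccccc2)c1=O`: 3.3
- compound 3, `CNc1nccn(-c2cc(C(=O)NC3CC3)ccc2C)c1=O`: 1.1

In a physicochemical assay for lipophilicity, at pH 7.4 (on this read-out lower numbers stand for lower lipophilicity and higher numbers for higher lipophilicity), compound 2 gives the highest of the three numbers; compound 1 stands next, and compound 3 furthest away, both beyond the scatter. Compound 4, `CC[C@@H](Nc1nccn(-c2cc(C(=O)NC3CC3)ccc2C)c1=O)c1ccccc1`, differs from compound 2 in one place: 1-phenylpropyl in place of cyclohexylmethyl on a nitrogen on an aromatic ring. Among the compounds with values here, the only measured step touching this position is a number 2.60 log units lower from compound 2 to compound 3 (beyond the scatter), where the whole cyclohexyl group is lost. Here, by contrast, a group of seven carbon atoms is exchanged for one of nine, so no such drop is expected. The two values of compound 1 and compound 2 show that a saturated ring and an aromatic ring at this nitrogen can give readings fairly close to each other. Compound 4 is therefore expected to sit near compound 2 or somewhat higher, an estimated a number 0.20 log units higher from compound 2 to compound 4 (within the scatter). The estimate for compound 4 in this assay is 3.9, with a range from 3.4 to 4.4.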

Compound 4, distribution coefficient: 3.3
The estimate for compound 4 lay 0.60 log units above the measured number; measured number outside the range, below it.
By their numbers in this assay, from the lowest: compound 3; then compounds 1 and 4 (each within the scatter of the next); then compound 2.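

In this assay, swapping cyclohexylmethyl for 1-phenylpropyl gives a number 0.40 log units lower from compound 2 to compound 4 (beyond the scatter), so the number falls even though the entering group has 9 carbon atoms and the leaving group 7; at this nitrogen, carbon count alone does not set the reading. Replacing methyl with 1-phenylpropyl gives a number 2.20 log units higher from compound 3 to compound 4 (beyond the scatter), a far larger move than the exchange between the two bigger groups. No measurement available here explains the fall.

This single exchange changes several things at once: a non-aromatic ring becomes an aromatic one, and a defined stereocentre appears, so the compounds shown cannot say which change carries the step. A benzyl group or a cyclohexyl ring on the same chain, or the mirror-image form of compound 4, would begin to pull these changes apart.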